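The compounds below may be only part of what the source reports. "The series", "measured", "known", "first", "only" and "open" are said of these compounds alone.

Measured compounds:
compound 1, `Oc1cccc(-c2cc(-c3cccnc3)nc(-c3cccc(Cl)c3)c2)c1`: 27.6%
compound 2, `Oc1ccc(-c2cc(-c3ccc(Cl)cc3)nc(-c3cccnc3)c2)cc1`: 18.8%
compound 3, `Oc1cccc(-c2cc(-c3cccc(Cl)c3)nc(-c3ccco3)c2)c1`: 5.5%

In an assay on isolated protein for inhibition of DNA topoisomerase 1 (Homo sapiens), with a stated time of 30 min, tested at 100 uM (a lower number here means a weaker effect, a higher number a stronger effect of the compound at the concentration tested), compound 3 gives 5.5%, the lowest of the three numbers. Compound 2 stands nearest with 18.8%, and compound 1 furthest with 27.6%, both gaps beyond the scatter. For the measured compounds named here, the one measured step that reaches compound 3 is a number 22.1 percentage points lower from compound 1 to compound 3 (beyond the scatter), where a six-membered ring bearing a nitrogen was replaced by a five-membered ring bearing an oxygen.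

Compound 4, `Oc1cccc(-c2cc(-c3ccsc3)nc(-c3cccc(Cl)c3)c2)c1`, has not been measured. It differs from compound 3 in one place: thiophen-3-yl in place of furan-2-yl on an aromatic carbon. Here one five-membered ring with a single hetero atom gives way to another, so the change is smaller in kind than the step that produced compound 3. Going by the values given here, no measured pair shows a sulfur-containing ring at this position, so the direction is uncertain; a step within the scatter, or a small rise toward the number of compound 1, seems most plausible.

For compound 4 the expected result in this assay is 11%, with a range from 0% to 28%, which amounts to an estimated step of a number 5.5 percentage points higher from compound 3 to compound 4 (within the scatter).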

Compound 4, a percentage reported as inhibition, at one concentration (the size of the read-out at that concentration, not a potency): 26.2%
The estimate for compound 4 lay 15.2 percentage points below the measured number; measured number inside the range.
By their numbers in this assay, from the lowest: compound 3; then compounds 2, 4 and 1 (each within the scatter of the next).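

In this assay, the exchange of furan-2-yl for thiophen-3-yl gives a number 20.7 percentage points higher from compound 3 to compound 4 (beyond the scatter) even though both groups are five-membered aromatic rings with one hetero atom, so the low number of compound 3 does not extend to every such ring at this position next to the ring nitrogen. The second comparison, a number 1.4 percentage points lower from compound 1 to compound 4 (within the scatter), shows that this five-membered ring can match pyridin-3-yl here, so ring size alone does not set the read-out among compounds 1, 3 and 4. Nothing available explains the gap between furan-2-yl and thiophen-3-yl.

Because the sulfur and the point of attachment change together, the compounds shown cannot say which of the two matters; thiophen-2-yl and furan-3-yl would separate them. Going by these compounds, whether a non-aromatic group, such as a piperidine or an aminomethyl group, would be tolerated at this position also remains open.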